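The compounds below may be only part of what the source reports. "The series", "measured", "known", "first", "only" and "open" are said of these compounds alone.

Of the compounds shown here, three from this study have been tested in a functional assay on HeLa cells (Homo sapiens); on this read-out lower numbers stand for an effect already at smaller amounts and higher numbers for an effect only at larger amounts of compound. Compound 1 has the structure `CCOC(=O)c1cc(CCl)nn1C1O[C@@H](COC(C)=O)[C@H](OC(C)=O)[C@@H](OC(C)=O)[C@@H]1OC(C)=O` and in this assay compound 1 gives 40 ug/mL. Compound 2, `CCOC(=O)c1cc(CCl)nn1[C@@H]1O[C@H](COC(C)=O)[C@@H](OC(C)=O)[C@H]1OC(C)=O`, is built on a different core; how the two cores differ is not broken down here. In this assay compound 2 gives 32 ug/mL, and the values of compound 1 and compound 2 lie within the usual scatter of each other, so nothing separates them. Compound 3, `CC(=O)OC[C@@H]1OC(n2nc(CCl)cc2C(N)=O)[C@@H](OC(C)=O)[C@H](OC(C)=O)[C@H]1OC(C)=O`, shares the core of compound 1 and differs from it in one place: amino in place of ethoxy on a carbonyl carbon. In this assay compound 3 gives 18 ug/mL. This change made a step of a 2.2-fold lower number from compound 1 to compound 3 (0.35 log units; beyond the scatter), a difference that goes beyond the scatter, though only modestly. The same change is now made on the core of compound 2 to give compound 4, `CC(=O)OC[C@H]1O[C@@H](n2nc(CCl)cc2C(N)=O)[C@H](OC(C)=O)[C@@H]1OC(C)=O`: amino in place of ethoxy on a carbonyl carbon. Going by the values given here, because the one measured example of this change gave a 2.2-fold lower number from compound 1 to compound 3 (0.35 log units; beyond the scatter), a step of similar size is expected here, namely a 2.1-fold lower number from compound 2 to compound 4 (0.33 log units; beyond the scatter). This rests on a single pair, so the expectation is loose, and whether the second core carries the change in the same way is not known from what has been measured. For compound 4 in this assay a value of about 15 ug/mL is therefore expected, most likely falling between 8 ug/mL and 30 ug/mL.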

Compound 4, concentration for half-maximal effect: 26 ug/mL
Estimate against measurement, compound 4: 1.7-fold (0.24 log units) below, within the range that was stated.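

On the core of compound 2, putting amino in place of ethoxy on a carbonyl carbon, which turns the ethoxycarbonyl group into a carbamoyl group, gives a 1.2-fold lower number from compound 2 to compound 4 (0.09 log units; within the scatter) in this assay, so on this core alone the change cannot be said to have shifted the number at all. Set beside the earlier step, the result on this second core does not stand apart from the first, since the gap between the two steps is no larger than repeated measurements could produce by themselves: the same change on two cores in this assay, a 2.2-fold lower number (0.35 log units; beyond the scatter) from compound 1 to compound 3 and a 1.2-fold lower number (0.09 log units; within the scatter) from compound 2 to compound 4, 1.8-fold (0.26 log units) apart, within the scatter of two such steps. Going by these compounds alone, this means the two cores are compatible with the change carrying over from one to the other, but it does not show that the change acts alike on both, as there are only two pairs, one step only modestly beyond the scatter and the other within it.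

The compounds shown leave open what other groups on this carbonyl carbon would do, such as a methylamino group, a longer chain than ethoxy, or hydroxy, which would give a carboxylic acid. They also leave open whether the same step would appear on further cores, or in any read-out other than this assay.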